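Swapping Trifluoromethyl for Methyl on the Aniline Ring

The source may report more compounds than this note shows. Statements on the series, on what has been measured and on what is new or still open speak of the compounds shown alone.

Measured in a functional assay on NCI-H1975 cells (Homo sapiens) for antiproliferative activity, read by MTT assay, with a stated time of 72 h; on this read-out lower numbers stand for stronger inhibition and higher numbers for weaker inhibition:
compound 1 `COc1cc2ncnc(Nc3ccc(Cl)c(C(F)(F)F)c3)c2cc1OCCCCC(=O)Nc1ccc(S(N)(=O)=O)cc1` gives 3220 nM;
compound 2 `C#Cc1cccc(Nc2ncnc3cc(OC)c(OCCCCC(=O)Nc4ccc(S(N)(=O)=O)cc4)cc23)c1` gives 18800 nM;
compound 3 `COc1cc2ncnc(Nc3ccc(C(F)(F)F)cc3)c2cc1OCCCCC(=O)Nc1ccc(S(N)(=O)=O)cc1` gives 12000 nM.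

Compound 3 lies between the other two: a 1.6-fold lower number from compound 2 to compound 3 (0.19 log units; within the scatter) means its value and that of compound 2 cannot be told apart, while a 3.7-fold higher number from compound 1 to compound 3 (0.57 log units; beyond the scatter) sets it clearly apart from compound 1. Compound 4 `COc1cc2ncnc(Nc3ccc(C)cc3)c2cc1OCCCCC(=O)Nc1ccc(S(N)(=O)=O)cc1` differs from compound 3 only on the aniline ring: methyl in place of trifluoromethyl on an aromatic carbon. Among the measured compounds shown here, no measured pair tests exactly this exchange. The step of a 3.7-fold higher number from compound 1 to compound 3 (0.57 log units; beyond the scatter) shows that taking a group off this ring raised the number, and a 1.6-fold lower number from compound 2 to compound 3 (0.19 log units; within the scatter) shows a different ring substituent making no difference beyond the scatter. A small rise, or none beyond the scatter, is therefore expected in this assay : a 1.3-fold higher number from compound 3 to compound 4 (0.12 log units; within the scatter). Compound 4 is estimated at 16000 nM, within a range of 5500 nM to 45000 nM.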

Compound 4, half-maximal inhibitory concentration: 19300 nM
Estimate against measurement, compound 4: 1.2-fold (0.08 log units) below; low and high end bracket the measured number.
By their numbers in this assay, from the lowest: compound 1; then compounds 3, 2 and 4 (each within the scatter of the next).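

In this assay, methyl and trifluoromethyl on this aromatic carbon, para to a large group, cannot be told apart (a 1.6-fold higher number from compound 3 to compound 4 (0.21 log units; within the scatter)). The 4-methylphenyl and 3-ethynylphenyl rings cannot be told apart either (a 1.0-fold higher number from compound 2 to compound 4 (0.01 log units; within the scatter)), whereas the 4-chloro-3-(trifluoromethyl)phenyl ring remains clearly separate from the 4-methylphenyl ring (a 6.0-fold higher number from compound 1 to compound 4 (0.78 log units; beyond the scatter)). No measurement here offers an explanation for these results.

On these data alone, how an amine or a methoxy group on this same carbon would read remains open. Also open is which part of the ring in compound 1, the chlorine or the trifluoromethyl, accounts for its separation.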